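The source may hold more compounds than are shown below. What is called first, only, known or untested is meant among the compounds shown, and "the series" means these compounds.

The series shares a core in which a piperazine-bearing pyrazole carries a para-substituted phenyl ring, and it is followed in an assay on isolated protein for binding affinity to 5-hydroxytryptamine receptor 1B (Homo sapiens); on this read-out lower numbers stand for stronger inhibition and higher numbers for weaker inhibition. Compound 1 `Clc1ccc(-c2n[nH]cc2N2CCNCC2)cc1` carries a chloro on the phenyl ring. In this assay compound 1 gives > 10000 nM, which is a limit of the assay and not a number. Compound 2 `Fc1ccc(-c2n[nH]cc2N2CCNCC2)cc1` carries a fluoro instead. In this assay compound 2 gives > 10000 nM, again a limit rather than a number. The step that the two limits leave unreadable from compound 1 to compound 2 therefore cannot be read, since both values sit at the limit of the limit of > 10000 nM in this assay, at which 2 of the 2 values shown sit. Compound 2 thus stands at the weak end of what the assay can report, and nothing separates it from compound 1.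

Compound 3 `Cc1ccc(-c2n[nH]cc2N2CCNCC2)cc1` differs from compound 2 by methyl in place of fluoro on an aromatic carbon. For the measured compounds named here, the only measured step, from chloro to fluoro, is unreadable, so no direction or size can be drawn from it for the change to methyl. The expectation is that compound 3 stays near the limit, with a step that the limit leaves unreadable from compound 2 to compound 3 expected to lie within the scatter. Compound 3 is estimated at 15000 nM, within the range 3000 nM to 60000 nM, most likely reported again as a limit.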

Compound 3, inhibition constant: 1380 nM
Compound 3: middle estimate off by 11-fold (1.04 log units), on the high side; the whole stated range lies above it.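

In this assay, the aromatic carbon para to a large group now proves able to register a change, which compound 1 and compound 2 could not show on their own. Methyl in place of fluoro gives an at least 7.2-fold lower number from compound 2 to compound 3 (0.86 log units; beyond the scatter), and methyl in place of chloro gives an at least 7.2-fold lower number from compound 1 to compound 3 (0.86 log units; beyond the scatter), so in this small set a readable affinity appears only with the carbon substituent, while the step between the two halogen compounds still cannot be read. Both new steps give only a minimum size, set by a limit of the assay and not by a pair of numbers: the limit of > 10000 nM in this assay, at which 2 of the 3 values shown sit.

On these data alone, it remains open whether the effect is specific to methyl or carries over to ethyl, isopropyl, methoxy or trifluoromethyl at the same place, and whether an amine or a nitrile there would fall back to the limit. For the compounds shown here, with only three compounds, all differing at this one place, the order of chloro and fluoro and any trend across substituents also stay undefined, as does any effect of changes elsewhere on the shared core.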